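Pyrimidine for Pyridine in a Lanosterol Synthase Series

The source may report more compounds than this note shows. Statements on the series, on what has been measured and on what is new or still open speak of the compounds shown alone.

Measured compounds:
compound 1 `O=C(N1CCN(c2ccncc2Cl)CC1)N1CCN(S(=O)(=O)c2ccc(Cl)cc2)CC1` 87%
compound 2 `O=C(C1CCN(c2ccncc2Br)CC1)N1CCN(S(=O)(=O)c2ccc(Br)cc2)CC1` 89%

In an assay for inhibition of lanosterol synthase (Rattus norvegicus), using microsomes, tested at 100 nM (a lower number here means less inhibition, a higher number more inhibition at the concentration tested (going by the name of the read-out)), compound 1 gives 87%. Compound 2, which carries a bromine on both aromatic rings and a carbon rather than a nitrogen linking its amide to the saturated ring, gives 89% in this assay. Compound 2 holds the higher of the two numbers, but the gap to compound 1 lies within the usual scatter, so the two cannot be ordered.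

Compound 3 `O=C(C1CCN(c2ncncc2Br)CC1)N1CCN(S(=O)(=O)c2ccc(Br)cc2)CC1` is the next step. It differs from compound 2 in one place: 5-bromopyrimidin-4-yl in place of 3-bromopyridin-4-yl on an amine nitrogen in a ring. Among the compounds with values here, no step between measured compounds tells how such a change affects this assay, so the expectation rests on compound 2 alone. Compound 3 is expected to stay close to compound 2, with at most a small downward step of a number 7 percentage points lower from compound 2 to compound 3 (within the scatter) that need not exceed the scatter. Compound 3 is therefore estimated at 82% in this assay, between 65% and 93%.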

Compound 3, a percentage reported as inhibition, at one concentration (the size of the read-out at that concentration, not a potency): 47%
Beside the measured number, compound 3's estimate is 35 percentage points above it, and the stated range ends above it.
By their numbers in this assay, from the lowest: compound 3; then compounds 1 and 2 (each within the scatter of the next).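

Within the data shown here, the step of a number 42 percentage points lower from compound 2 to compound 3 (beyond the scatter) in this assay is the first reading of how the group on this amine nitrogen responds to change: 5-bromopyrimidin-4-yl in place of 3-bromopyridin-4-yl alters one ring atom, from carbon to nitrogen, and the step lies beyond the scatter. The group on this ring nitrogen therefore cannot be exchanged freely in this series, even for a ring with the same number of heavy atoms and the rest of the structure unchanged. Nothing available explains why this single ring atom matters so much.

Going by these compounds, whether the same exchange would have a similar effect in the core of compound 1 stays open. So does how a plain phenyl ring or a pyridazine ring, carrying the same bromine, would fare on this amine nitrogen.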